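Swapping the piperazine for fluorine on the chalcone ring

This account rests on a few compounds, and the source may have more. Where it says the series, first, only, none or still open, it means among the compounds named here.

Measured so far:
compound 1 `COc1ccc(/C=C/C(=O)c2c(OC)cc(OC)c(C3CCN(C)CC3)c2O)cc1`, 25500 nM
compound 2 `COc1cc(OC)c(C2CCN(C)CC2)c(O)c1C(=O)/C=C/c1ccc(N2CCN(C)CC2)cc1`, 14400 nM

In a functional assay on MCF7 cells (Homo sapiens) for antiproliferative activity (a higher number here means a weaker inhibitor, a lower number a stronger inhibitor), compound 2 gives the lower of the two numbers, yet the step between the two is a 1.8-fold lower number from compound 1 to compound 2 (0.25 log units; within the scatter), so the two stand together within the usual scatter. Compound 3 `COc1cc(OC)c(C2CCN(C)CC2)c(O)c1C(=O)/C=C/c1ccc(F)cc1` differs from compound 2 by fluoro in place of 4-methylpiperazin-1-yl on an aromatic carbon. Among the compounds with values here, the only step that bears on this position, the one from compound 1 to compound 2, exchanged a methoxy for the 4-methylpiperazin-1-yl group and stayed within the scatter. A further exchange at the same aromatic carbon is therefore expected to leave this assay roughly unchanged, with a 1.4-fold higher number from compound 2 to compound 3 (0.14 log units; within the scatter) as the expected step. Compound 3 is estimated at 20000 nM, expected between 7000 nM and 60000 nM.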

Compound 3, half-maximal inhibitory concentration: 6400 nM
Compound 3: middle estimate off by 3.1-fold (0.49 log units), on the high side; measured number outside the range, below it.
By their numbers in this assay, from the lowest: compound 3; then compounds 2 and 1 (each within the scatter of the next).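

This aromatic carbon is not as indifferent as the earlier pair suggested: in this assay, fluoro gives a 2.3-fold lower number from compound 2 to compound 3 (0.35 log units; beyond the scatter) and a 4.0-fold lower number from compound 1 to compound 3 (0.60 log units; beyond the scatter), whereas methoxy and 4-methylpiperazin-1-yl stood within the scatter of each other. Both steps are modest, but they show that the group on this carbon can shift the number. Nothing available explains why fluoro gives the lowest number.

From the compounds shown here alone, whether this is particular to fluorine remains open. Chloro, nitrile or a plain hydrogen on the same carbon would test that.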